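The source may hold more compounds than are shown below. What is called first, only, known or untested is meant among the compounds shown, and "the series" means these compounds.

Working notes on the series. Two compounds carry measurements in an in vitro assay on HEK293 cells for displacement of a labelled ligand from adenosine receptor A2b (Homo sapiens); on this read-out lower numbers stand for stronger inhibition and higher numbers for weaker inhibition. Compound 1 `CCCn1c(=O)c2nc(-c3cnn(Cc4cccc(C)c4)c3)[nH]c2n(CCC)c1=O` gives 36 nM in this assay. Compound 2 `CC(C)Cn1c(=O)c2nc(-c3cnn(Cc4cccc(C(F)(F)F)c4)c3)[nH]c2n(CC(C)C)c1=O` gives 300 nM in this assay, the highest of the two numbers; its nearest neighbour is compound 1, whose number is lower by an amount well beyond the scatter. Among the measured compounds shown here, compound 1 and compound 2 differ in more than one place, so the two values are noted as they stand and no single step is read from them.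

Compound 3 `CC(C)Cn1c(=O)c2nc(-c3cnn(Cc4cccc(F)c4)c3)[nH]c2n(CC(C)C)c1=O` has not yet been measured in this assay. It differs from compound 2 in one place: fluoro in place of trifluoromethyl on an aromatic carbon. For the measured compounds named here, no measured pair in the set isolates this change, so the expectation rests on the values of compound 1 and compound 2 alone. Going by the values given here, the only other measured compound, compound 1, carries a small group on that ring together with a lower number, 36 nM, which suggests a step downward for compound 3, though its size is uncertain.

For compound 3 the expected step in this assay is a 2.0-fold lower number from compound 2 to compound 3 (0.30 log units; within the scatter), toward a lower number. Compound 3 is estimated at 150 nM in this assay, with a range from 50 nM to 450 nM.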

Compound 3, inhibition constant: 990 nM
Beside the measured number, compound 3's estimate is 6.6-fold (0.82 log units) below it; the whole stated range lies below it.
By their numbers in this assay, from the lowest: compound 1; then compound 2; then compound 3.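

In this assay, among the compounds shown here, the change from 3-(trifluoromethyl)benzyl to 3-fluorobenzyl gives a 3.3-fold higher number from compound 2 to compound 3 (0.52 log units; beyond the scatter) and is the first single-place step. It shows that the group on this aromatic carbon, meta to a large group, registers in this read-out, with the rest of the structure unchanged. Going from four heavy atoms to one at this position does not lower the number here, and the fluoro compound stands on the higher side of the trifluoromethyl compound, although this rests on one pair alone. Nothing in hand bears on what lies behind this step.

For the compounds shown here, only two groups can be compared on this carbon with everything else fixed, so it remains open where hydrogen, chloro, methoxy or a nitrile would fall relative to fluoro and trifluoromethyl. Compound 1 carries methyl at this position but also different chains on the core, so neither the effect of methyl alone nor the persistence of this step with propyl chains in place of the chains of compound 2 can be read from these compounds.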